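The compounds below may be only part of what the source reports. "The series", "measured", "known", "first", "only" and "open" are said of these compounds alone.

Measured so far:
compound 1, `CCCOP(=O)(O)OCCSC(=S)N1CCCC1`: 67000 nM
compound 2, `CCCCCCCCOP(=O)(O)OCCSC(=S)N1CCCCCC1`: 27000 nM

Both were tested in a functional assay on MDA-MB-231 cells (Homo sapiens) for inhibition, read by MTT assay, with stated times of 18 h and 4 h; on this read-out lower numbers stand for stronger inhibition and higher numbers for weaker inhibition. Compound 2 gives the lower of the two numbers, and compound 1 sits well beyond the usual scatter above it, so the two are clearly told apart. Compound 3, `CCCOP(=O)(O)OCCSC(=S)N1CCCCCC1`, has not yet been measured. It differs from compound 2 in one place: hydrogen in place of pentyl on a saturated chain carbon, three bonds along the chain from an oxygen on an unsaturated carbon. Among the measured compounds shown here, compound 3 thus carries the propyl chain of compound 1 together with the ring of compound 2, and no measured pair isolates this single change, so its effect can only be expected rather than read off. Compound 1, with the same propyl chain, gives 67000 nM in this assay. On that basis the step from compound 2 to compound 3 is expected to be a 1.9-fold higher number from compound 2 to compound 3 (0.27 log units; within the scatter), toward weaker inhibition. Compound 3 is accordingly estimated at 50000 nM, with a likely range from 20000 nM to 120000 nM.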

Compound 3, half-maximal inhibitory concentration: 38000 nM
For compound 3 the middle estimate is 1.3-fold (0.12 log units) above the measured one, and the stated range covers the measured number.
By their numbers in this assay, from the lowest: compounds 2, 3 and 1 (each within the scatter of the next, the first and the last beyond it).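

In this assay, the change from octyl to propyl, which is hydrogen in place of pentyl on a saturated chain carbon, gives a 1.4-fold higher number from compound 2 to compound 3 (0.15 log units; within the scatter). Among the compounds shown here, this is the first pair that isolates the chain at this position, and it shows that, with the ring of compound 2 held constant, these two chains cannot be told apart on this read-out. No separate measurement bears on why this is so.

The compounds shown leave open whether a butyl or hexyl chain, or an amine or carboxylic acid at the end of the chain, would give a clearly different number. As far as these compounds go, it also remains open whether the same chain change would read alike on the ring of compound 1.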